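Extending the pyridin-3-yl group of compound 2 toward compound 3

The source may report more compounds than this note shows. Statements on the series, on what has been measured and on what is new or still open speak of the compounds shown alone.

Measured so far:
compound 1 `CCCn1ccc2cc(N3CCC(O)CC3)cc(Cl)c2c1=O` — 106%
compound 2 `CCCn1ccc2cc(-c3cccnc3)cc(Cl)c2c1=O` — 83%
Not yet measured:
compound 3 `CCCn1ccc2cc(-c3ccc(OCc4cccnc4)nc3)cc(Cl)c2c1=O`

In a functional assay on CHO cells for agonist activity at metabotropic glutamate receptor 2 (Homo sapiens), read by GTPgammaS binding (a lower number here means a smaller maximal response, a higher number a larger maximal response), compound 1 gives 106% and compound 2 gives 83%. Among the measured compounds shown here, compound 2 therefore stands lowest of the two numbers, with compound 1 as its only neighbour; the gap is a number 23 percentage points lower from compound 1 to compound 2 (beyond the scatter), beyond the scatter but modest.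

The change from compound 2 to compound 3 is (pyridin-3-yl)methoxy in place of hydrogen on an aromatic carbon. For the measured compounds named here, the one measured step, a number 23 percentage points lower from compound 1 to compound 2 (beyond the scatter), concerns the exchange of the whole group on the shared core and not an addition onto the pyridin-3-yl ring, so it bears on the present step only loosely: it shows that this position tolerates a change without loss of the response, and that the size of the shift was modest. Going by the values given here, no measured step tells what an added (pyridin-3-yl)methoxy does here.

For compound 3 the maximal response in this assay is expected to stay close to compound 2, a step of a number 2 percentage points higher from compound 2 to compound 3 (within the scatter) within the scatter, estimated at 85% with a range of 65% to 105%.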

Compound 3, largest response reached (Emax), in percent of the reference or control that the assay uses: 120%
Beside the measured number, compound 3's estimate is 35 percentage points below it, outside the stated range (above it).
By their numbers in this assay, from the lowest: compound 2; then compound 1; then compound 3.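

Adding (pyridin-3-yl)methoxy on the aromatic carbon next to the ring nitrogen, para to a large group, is the first change shown on the pyridin-3-yl ring itself, and in this assay it gives a number 37 percentage points higher from compound 2 to compound 3 (beyond the scatter) as a large step. Among the compounds shown here, the one earlier step, a number 23 percentage points lower from compound 1 to compound 2 (beyond the scatter) and modest in size, exchanged the whole group on the shared core, whereas this one adds to the ring already there and moves the maximal response upward. This carbon therefore accepts a group that also brings a second six-membered aromatic ring with no loss of response, and the compounds offer no measured explanation for the gain.

Going by these compounds, whether the gain needs the whole (pyridin-3-yl)methoxy group stays open: a plain methoxy or a benzyloxy on the same carbon would separate the contribution of the ether oxygen from that of the terminal ring and its nitrogen. Also open is whether a morpholine or a primary amine on that carbon would keep the response, since the only group shown there is (pyridin-3-yl)methoxy.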